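This account rests on a few compounds, and the source may have more. Where it says the series, first, only, none or still open, it means among the compounds named here.

Of the compounds shown here, three built on one shared core have been tested in a functional assay on the whole organism (artery, strain albino) with Rattus norvegicus as the target, with a stated time of 30 min, at a dose of 10 mg/kg by the oral route; on this read-out lower numbers stand for less inhibition and higher numbers for more inhibition at the one dose given (going by the name of the read-out). Compound 1 `CC1=C(C(=O)Nc2ccc(Br)cc2)C(c2ccc(Cl)cc2Cl)N=C(SCc2ccccc2)N1` gives 3.6%. Compound 2 `CC1=C(C(=O)Nc2ccc(Br)cc2)C(c2ccc(Cl)cc2Cl)N=C(SCc2ccccc2Cl)N1` gives 5.7%, and compound 3 `COc1ccc(C2N=C(SCc3ccccc3)NC(C)=C2C(=O)Nc2ccc(Br)cc2)cc1` gives 2.6%. On these numbers compound 3 has the lowest value of the three, yet its gap to compound 1 and its gap to compound 2 both fall within the scatter, so no order among them can be read. The step from compound 1 to compound 3, a number 1 percentage points lower from compound 1 to compound 3 (within the scatter), is the exchange of 2,4-dichlorophenyl for 4-methoxyphenyl on a saturated ring carbon, and it changed the read-out by no more than the scatter.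

Compound 4 `COc1ccc(C2N=C(SCc3ccccc3Cl)NC(C)=C2C(=O)Nc2ccc(Br)cc2)cc1` differs from compound 3 by chloro in place of hydrogen on an aromatic carbon. Within the data shown here, the one measured step that bears on this change is a number 2.1 percentage points higher from compound 1 to compound 2 (within the scatter), the same chloro-for-hydrogen exchange carried out on compound 1, and it stayed within the scatter. Nothing else among the measured compounds speaks to the change. Compound 4 is therefore expected to show in this assay a step of a number 1.9 percentage points higher from compound 3 to compound 4 (within the scatter), that is, no movement beyond the scatter. The estimated value of compound 4 is 4.5%, with a range from 0% to 12%.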

Compound 4, a percentage reported as inhibition, in the whole organism at one dose (the size of the read-out at that dose, not a potency): 4.6%
Beside the measured number, compound 4's estimate is 0.1 percentage points below it, and the stated range covers the measured number.
By their numbers in this assay, from the lowest: compounds 3, 1, 4 and 2 (each within the scatter of the next).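

The change from benzylsulfanyl to (2-chlorobenzyl)sulfanyl can now be read on a second background in this assay, where it gives a number 2 percentage points higher from compound 3 to compound 4 (within the scatter), so the chloro exchange stays inside the scatter with either 2,4-dichlorophenyl or 4-methoxyphenyl on the saturated ring carbon: the same change on two cores in this assay, a number 2.1 percentage points higher (within the scatter) from compound 1 to compound 2 and a number 2 percentage points higher (within the scatter) from compound 3 to compound 4, 0.1 percentage points apart, within the scatter of two such steps The exchange of 2,4-dichlorophenyl for 4-methoxyphenyl can likewise now be read with the 2-chlorobenzyl group in place, where it gives a number 1.1 percentage points lower from compound 2 to compound 4 (within the scatter), in agreement with its earlier reading: the same change on two cores in this assay, a number 1 percentage points lower (within the scatter) from compound 1 to compound 3 and a number 1.1 percentage points lower (within the scatter) from compound 2 to compound 4, 0.1 percentage points apart, within the scatter of two such steps Together the four compounds form a closed square in which neither exchange moves the read-out beyond the scatter and the size of each step shows no dependence on the other exchange.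

The compounds shown carry only hydrogen or chloro at this aromatic carbon, and they leave open whether any change here can move the read-out beyond the scatter at all. Whether a carboxylic acid or an amine on this ring, or a longer chain in place of the benzyl group, would read differently in this assay cannot be told from them.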